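From 2-methoxyphenyl to phenyl in compound 3

A few compounds are considered here, and "the series" means these few. Any claim that something is new, unique, unknown or untested is made for them only; others in the source may bear on it.

Compound 1 `COc1cc(/C=C/C(=O)/C=C/c2cccc3ccccc23)ccc1OCc1cn(CCCCCOc2cc(=O)oc3ccccc23)nn1` gives 44%
Compound 2 `COc1ccccc1/C=C/C(=O)/C=C/c1ccc(OCc2cn(CCCCCOc3cc(=O)oc4ccccc34)nn2)c(OC)c1` gives 37%

In a functional assay on THP-1 cells (Homo sapiens) for inhibition, read by sulforhodamine B assay, with a stated time of 48 h, tested at 50 uM (on this read-out higher numbers stand for more inhibition of growth at the one concentration tested and lower numbers for less inhibition of growth), compound 2 gives 37% and sits within the scatter of compound 1. Compound 3 `COc1cc(/C=C/C(=O)/C=C/c2ccccc2)ccc1OCc1cn(CCCCCOc2cc(=O)oc3ccccc23)nn1` differs from compound 2 by hydrogen in place of methoxy on an aromatic carbon with hydrogen in place of methoxy on an aromatic carbon. For the measured compounds named here, the one measured step bearing on this change is a number 7 percentage points lower from compound 1 to compound 2 (within the scatter) and it exchanged naphthalen-1-yl for 2-methoxyphenyl. On that basis no step beyond the scatter is expected in this assay here. The expected step is a number 2 percentage points higher from compound 2 to compound 3 (within the scatter) and no larger. Compound 3 is estimated at 39% with a range from 27% to 51% in this measurement.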

Compound 3, percent growth inhibition at one concentration: 26%
Beside the measured number, compound 3's estimate is 13 percentage points above it; measured number below the stated range.
By their numbers in this assay, from the lowest: compound 3; then compounds 2 and 1 (each within the scatter of the next).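

In this assay, the bare phenyl end falls short of both larger aryl groups. Hydrogen in place of methoxy gives a number 11 percentage points lower from compound 2 to compound 3 (beyond the scatter) and phenyl in place of naphthalen-1-yl gives a number 18 percentage points lower from compound 1 to compound 3 (beyond the scatter), so this position responds to substitution in a way that the earlier pair, which stayed within the scatter of each other, did not reveal. Nothing measured explains the drop. Going by these compounds, it remains open whether another group at this carbon, such as an ethoxy, an amine or a fluorine, would match methoxy, and whether methoxy elsewhere on the ring would serve equally.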